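The source may report more compounds than this note shows. Statements on the series, on what has been measured and on what is new or still open speak of the compounds shown alone.

Compound 1 `C=CC(=O)Nc1nc(-c2ccccc2Cl)cs1` and compound 2 `C=CC(=O)Nc1nc(-c2ccccc2F)cs1` share a core and differ only in one substituent. In a functional assay on HT-29 cells (Homo sapiens) for antiproliferative activity, read by MTT assay, with a stated time of 72 h (on this read-out lower numbers stand for stronger inhibition and higher numbers for weaker inhibition), compound 1 gives 10200 nM, and compound 2 gives 18700 nM. The change fluoro in place of chloro on an aromatic carbon thus produced a 1.8-fold higher number from compound 1 to compound 2 (0.26 log units; within the scatter). Compound 3 `C=CC(=O)N(Cc1cc(C)no1)c1nc(-c2ccc(Cl)cc2O)cs1` carries a different core; the difference between the two cores is not broken down here. In this assay compound 3 gives only a limit, > 30000 nM. Within the data shown here, compound 3 is the one value that sits at the limit of > 30000 nM in this assay, at which 1 of the 3 values shown sits. Compound 4 `C=CC(=O)N(Cc1cc(C)no1)c1nc(-c2ccc(F)cc2O)cs1` is the not yet measured partner of compound 3, made by fluoro in place of chloro on an aromatic carbon. This is the same kind of change as in the first pair, though its surroundings differ: there the new group stood ortho to a large group, here it stands meta to a hydroxy group and para to a large group. From compound 3 to compound 4 the expected step is a step that the limit leaves unreadable from compound 3 to compound 4, because the measured step of a 1.8-fold higher number from compound 1 to compound 2 (0.26 log units; within the scatter) stays within the scatter. Compound 4 is therefore expected to give 45000 nM in this assay, most likely again only a limit.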

Compound 4, half-maximal inhibitory concentration: > 30000 nM
Compound 4 ended at the assay's limit; the forecaster's own chance of this, stated with the estimate: 85%; the middle value lies beyond the limit too.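

Compound 3 and compound 4 both end at a limit and not at a number, so no step can be read between them: the limit of > 30000 nM in this assay, at which 2 of the 4 values shown sit. The compounds shown leave open whether going from 4-chloro-2-hydroxyphenyl to 4-fluoro-2-hydroxyphenyl changes the read-out at all.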